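The source may report more compounds than this note shows. Statements on the series, on what has been measured and on what is new or still open speak of the compounds shown alone.

Measured compounds:
compound 1 `Cc1ccccc1NC(=O)N[C@H](C)c1ccccc1` — 100%
compound 2 `CCc1ccccc1NC(=O)N[C@H](C)c1ccccc1` — 100%
compound 3 `CCCCc1ccc(NC(=O)N[C@H](C)c2ccccc2)cc1` — 32%

All three values come from an ADME assay on the whole organism with Oryza sativa as the target, tested at 1 uM; a higher number here means a weaker effect of the compound at the concentration tested, a lower number a stronger effect. Compound 3 gives the lowest number of the three; compounds 1 and 2 sit well above it. The difference between the core of compound 1 and the core of compound 3 is not broken down here.

Compound 2 differs from compound 1 by methyl in place of hydrogen on a saturated chain carbon bound to an aromatic carbon, and this step gave no change at the digits printed from compound 1 to compound 2 (within the scatter). Compound 4 `CCCCCc1ccc(NC(=O)N[C@H](C)c2ccccc2)cc1` is not yet measured; it differs from compound 3 by methyl in place of hydrogen on a saturated chain carbon, four bonds along the chain from an aromatic carbon. The two places are not the same word for word: in the first the carbon is bound to an aromatic carbon, in the second it lies four bonds along the chain from an aromatic carbon, so this is the same kind of change rather than the same change.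

A small step is expected from compound 3 to compound 4, a number 2 percentage points lower from compound 3 to compound 4 (within the scatter), resting on the unchanged pair of compounds 1 and 2 in this assay, no change at the digits printed from compound 1 to compound 2 (within the scatter). Compound 4 is estimated at 30%, between 10% and 60%.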

Compound 4, a percentage reported as activity, at one concentration (the size of the read-out at that concentration, not a potency): 101%
Compound 4: the middle estimate sits 71 percentage points below what was measured, outside the stated range (above it).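

Methyl in place of hydrogen does not carry over as a fixed step between these two cores in this assay: the same change on two cores in this assay, no change at the digits printed (within the scatter) from compound 1 to compound 2 and a number 69 percentage points higher (beyond the scatter) from compound 3 to compound 4, 69 percentage points apart, beyond the scatter of two such steps

For the compounds shown here, on the core of compound 3 this change alone gives a number 69 percentage points higher from compound 3 to compound 4 (beyond the scatter), so the flat step on the core of compound 1 is no guide to the step on this core. This does not show why the two steps part, and since the carbon is bound to an aromatic carbon in one case and lies four bonds along the chain from an aromatic carbon in the other, the effects of core and place are not separated.

On these data alone, it remains open how a propyl or hexyl chain on the core of compound 3 would read in this assay, and so whether compound 3 is an isolated low point. Also open, as far as these compounds go, is how an amine or a carboxylic acid in place of the chain would read.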